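The source may report more compounds than this note shows. Statements on the series, on what has been measured and on what is new or still open speak of the compounds shown alone.

The compounds here share one core and were tested in a functional assay on HGC-27 cells (Homo sapiens) for cytotoxicity, read by MTT assay, with a stated time of 48 h; on this read-out lower numbers stand for stronger inhibition and higher numbers for weaker inhibition. Compound 1 `COc1ccc(/C=C/C(=O)/C=C/c2cc3ccccc3nc2Cl)cc1` gives > 10000 nM, and this is a limit of the assay, not a number. Compound 2 `COc1ccc(/C=C/C(=O)/C=C/c2cc3ccccc3nc2Cl)c(OC)c1` gives > 10000 nM, which is also a limit. Compound 3 `COc1ccc(/C=C/C(=O)/C=C/c2cc3ccccc3nc2Oc2ccccc2)cc1` gives > 10000 nM, again a limit. Going by the values given here, compound 3 therefore has no exact position, and the series so far rests on (the limit of > 10000 nM in this assay, at which 3 of the 3 values shown sit).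

Compound 4 `COc1ccc(/C=C/C(=O)/C=C/c2cc3ccccc3nc2Oc2ccccc2)c(OC)c1` is made from compound 3 by one change: methoxy in place of hydrogen on an aromatic carbon. This puts methoxy in place of hydrogen on an aromatic carbon, turning 4-methoxyphenyl to 2,4-dimethoxyphenyl.

The same exchange has been measured once, on the chloro member of the series, as a step that the two limits leave unreadable from compound 1 to compound 2. The swap of chloro for phenoxy appears as a step that the two limits leave unreadable from compound 1 to compound 3. Neither step has a readable size, so neither gives a direction. What they do show is that neither change brought a measurable value within reach of this assay.

No real shift is therefore expected, and the estimated change is a step that the limit leaves unreadable from compound 3 to compound 4. A further limit is the most likely report. If a number does appear, the expected value for compound 4 is 14000 nM, within an estimated range from 6000 nM to 35000 nM.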

Compound 4, half-maximal inhibitory concentration: > 10000 nM
Compound 4: a limit, no number; the forecaster's own chance of this, stated with the estimate: 75%; the middle value does not contradict the limit.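

Compound 4 gives > 10000 nM in this assay, which is a limit and not a number. The steps to compound 4 from compound 3 and from compound 2 cannot be read, and the series still rests on one result: the limit of > 10000 nM in this assay, at which 4 of the 4 values shown sit. Left open is whether the added methoxy or the phenoxy in place of chloro changes the cytotoxicity of these compounds at all.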